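The source may report more compounds than this note shows. Statements on the series, on what has been measured and on what is new or still open speak of the compounds shown alone.

Compound 3, `CC(C)(N)C(=O)N[C@H](COCc1ccccc1)c1nnn(CCCCC#N)n1`, carries a 3-cyanopropyl chain on the aromatic nitrogen of the shared core. In an assay on isolated protein for displacement of a labelled ligand from growth hormone secretagogue receptor type 1 (Homo sapiens), with a stated time of 1 h (a lower number here means a stronger inhibitor, a higher number a weaker inhibitor), compound 3 gives > 5000 nM, which is a limit of the assay and not a number. Compound 1, `CC(C)(N)C(=O)N[C@H](COCc1ccccc1)c1nnn(Cc2ccccc2)n1`, gives 4750 nM in this assay. Compound 2, `CC(C)(N)C(=O)N[C@H](COCc1ccccc1)c1nnn(Cc2ccccc2NS(C)(=O)=O)n1`, gives > 5000 nM in this assay, again a limit rather than a number. The step of an at least 1.0-fold higher number from compound 1 to compound 3 (0.02 log units; that floor lies within the scatter) therefore sets only a floor, and the step that the two limits leave unreadable from compound 2 to compound 3 cannot be read because of the limit of > 5000 nM in this assay, at which 2 of the 3 values shown sit. The step of an at least 1.0-fold higher number from compound 1 to compound 2 (0.02 log units; that floor lies within the scatter) likewise sets only a floor. The unmeasured compound 4, `CC(C)(N)C(=O)N[C@H](COCc1ccccc1)c1nnn(CC#N)n1`, differs from compound 3 by cyano in place of 3-cyanopropyl on a saturated chain carbon bound to an aromatic nitrogen. Among the measured compounds shown here, none of the floor steps tells how the shorter chain will fare, and the one readable number among the three already sits close to the limit. One therefore expects no step beyond the scatter and estimates a step that the limit leaves unreadable from compound 3 to compound 4. For compound 4 the estimated value in this assay is 8000 nM, with a range from 2500 nM to 30000 nM.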

Compound 4, inhibition constant: > 5000 nM
Compound 4: only a limit was reported (the forecaster's own chance of this, stated with the estimate: 65%); the middle value is on the limit's open side.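

In this assay compound 4 gives > 5000 nM, a limit and not a number, so cyano in place of 3-cyanopropyl on a saturated chain carbon bound to an aromatic nitrogen does not bring the value out of the limit. Among the compounds shown here, the one step that can be read is an at least 1.0-fold higher number from compound 1 to compound 4 (0.02 log units; that floor lies within the scatter), and it sets only a floor. The steps to compound 4 from compound 2 and from compound 3 cannot be read, because their values all rest on the same limit: the limit of > 5000 nM in this assay, at which 3 of the 4 values shown sit.

The compounds shown leave open whether any group at this position gives a number under that limit, and how far compound 2, compound 3 and compound 4 lie from compound 1. An amine or a carboxylic acid at the end of the chain, or a chain longer than 3-cyanopropyl, could test this.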